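Bromophenyl to Methoxy-Methylphenyl: A Tolerance Outlook

The source may report more compounds than this note shows. Statements on the series, on what has been measured and on what is new or still open speak of the compounds shown alone.

Compound 1 `CC1(C)OC(=O)C2(C(=O)O1)[C@@H](c1ccco1)CC(=O)C[C@H]2c1ccccc1` sits at a limit in an ADME assay on MT2 cells (Homo sapiens) for cytotoxicity; a higher number here means that more compound is tolerated, a lower number that less compound is tolerated: compound 1 gives > 111000 nM, a limit rather than a number. Compound 2 `CC1(C)OC(=O)C2(C(=O)O1)[C@@H](c1ccco1)CC(=O)C[C@H]2c1ccc(F)cc1` also gives only a limit, > 111000 nM. Compound 3 `CC1(C)OC(=O)C2(C(=O)O1)[C@@H](c1ccco1)CC(=O)C[C@H]2c1ccc(Br)cc1` likewise gives only a limit, > 111000 nM. Every step between them, a step that the two limits leave unreadable from compound 1 to compound 2, a step that the two limits leave unreadable from compound 1 to compound 3 and a step that the two limits leave unreadable from compound 2 to compound 3, is unreadable, since all three values rest at the limit of > 111000 nM in this assay, at which 3 of the 3 values shown sit. Compound 4 `COc1ccc([C@@H]2CC(=O)C[C@H](c3ccco3)C23C(=O)OC(C)(C)OC3=O)c(C)c1` differs from compound 3 by 4-methoxy-2-methylphenyl in place of 4-bromophenyl on a saturated ring carbon. Within the data shown here, no measured step bears on this change with a readable size, as the halogen steps sit at the limit of > 111000 nM in this assay, at which 3 of the 3 values shown sit. Compound 3 stands with the others at that limit. Compound 4 is expected to be tolerated about as fully, with an estimated 111000 nM (range 50000 nM to 300000 nM), the expected step of a number no higher from compound 3 to compound 4 (the limit leaves the size open) being none beyond the scatter.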

Compound 4, half-maximal cytotoxic concentration: > 111000 nM
Compound 4 gave a limit, no number; the forecaster's own chance of this, stated with the estimate: 80%; the middle value sits exactly at the limit.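

The steps from compound 1, compound 2 and compound 3 to compound 4 cannot be read, as all four compounds give only a limit in this assay: the limit of > 111000 nM in this assay, at which 4 of the 4 values shown sit.

The compounds shown leave open whether any of these groups on the saturated ring carbon changes the tolerated concentration in this assay at all.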